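The source may report more compounds than this note shows. Statements on the series, on what has been measured and on what is new or still open speak of the compounds shown alone.

In a functional assay on A549 cells (Homo sapiens) for antiproliferative activity, read by MTT assay, with a stated time of 72 h (on this read-out lower numbers stand for stronger inhibition and higher numbers for weaker inhibition), compound 3 `COc1cc(-n2cnc3ccc(-c4ccc(Cl)cc4Cl)cc32)cc(OC)c1OC` gives > 10000 nM, which is a limit of the assay and not a number. Compound 1 `COc1cc(-n2cnc3ccc(-c4cc(F)ccc4F)cc32)cc(OC)c1OC` gives 7940 nM, and compound 2 `COc1cc(-n2cnc3ccc(-c4cccc(O)c4)cc32)cc(OC)c1OC` gives 250 nM. Compound 4 `COc1cc(-n2cnc3ccc(-c4ccc(O)cc4)cc32)cc(OC)c1OC` is not yet measured. It differs from compound 3 as follows: 4-hydroxyphenyl in place of 2,4-dichlorophenyl on an aromatic carbon, with 4-hydroxyphenyl in place of 2,4-dichlorophenyl on an aromatic carbon.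

The closest evidence is the swap of 3-hydroxyphenyl for 2,4-dichlorophenyl, which shows an at least 40-fold higher number from compound 2 to compound 3 (1.60 log units; beyond the scatter), a large step beyond the scatter. Replacing 2,5-difluorophenyl with 3-hydroxyphenyl shows a 32-fold lower number from compound 1 to compound 2 (1.50 log units; beyond the scatter), also large. The two compounds without a hydroxyl differ by an at least 1.2-fold higher number from compound 1 to compound 3 (0.10 log units; that floor lies within the scatter), a floor within the scatter.

Compound 2 is the only measured hydroxyphenyl, and its hydroxyl sits elsewhere on the ring, so the transfer is uncertain. A large step to a lower number is still expected in this assay, though probably not as far down as for compound 2, which gives 250 nM. The expected change is an at least 16-fold lower number from compound 3 to compound 4 (1.22 log units; beyond the scatter). Compound 4 is estimated at 600 nM, with an expected range of 120 nM to 4000 nM.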

Compound 4, half-maximal inhibitory concentration: 5090 nM
The estimate for compound 4 lay 8.5-fold (0.93 log units) below the measured number; measured number outside the range, above it.
By their numbers in this assay, from the lowest: compound 2; then compounds 4 and 1 (each within the scatter of the next). At a limit, above all of these: compound 3.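

In this assay the place of the hydroxyl on the phenyl ring matters, as 4-hydroxyphenyl in place of 3-hydroxyphenyl gives a 20-fold higher number from compound 2 to compound 4 (1.31 log units; beyond the scatter) and the gain seen with compound 2 does not carry over to compound 4. A hydroxyl on this ring is therefore not enough by itself: 4-hydroxyphenyl in place of 2,5-difluorophenyl gives a 1.6-fold lower number from compound 1 to compound 4 (0.19 log units; within the scatter), so this hydroxyphenyl cannot be told apart from the difluorophenyl. Against 2,4-dichlorophenyl, only a floor can be read, an at least 1.9-fold lower number from compound 3 to compound 4 (0.29 log units; that floor lies within the scatter), as that end of the step is a limit of the assay and not a number: the limit of > 10000 nM in this assay, at which 1 of the 4 values shown sits.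

Still open, on these data alone, is whether an amine or a carboxylic acid at the 3-position of the phenyl ring would keep the activity of compound 2. A methoxy group in place of either hydroxyl also remains untested among the compounds shown.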